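Swapping the group on the ring amine nitrogen

The source may hold more compounds than are shown below. What is called first, only, known or untested is meant among the compounds shown, and "the series" means these compounds.

Compound 1 `O=C(C1CC1)N1CCc2nc(C#Cc3ccccc3)sc2C1`: in an assay on HEK293 cells for negative allosteric modulation of metabotropic glutamate receptor 5 (Homo sapiens), read by FLIPR, with a stated time of 1 h (a higher number here means a weaker inhibitor, a lower number a stronger inhibitor), compound 1 gives 290 nM.
Compound 2 `CC1CCC(C(=O)N2CCc3nc(C#Cc4ccccc4)sc3C2)CC1`: compound 2 reaches only a limit, > 10000 nM.
Compound 3 `O=C(CC1CCOCC1)N1CCc2nc(C#Cc3ccccc3)sc2C1`: compound 3 likewise reaches only a limit, > 10000 nM.

For the measured compounds named here, compound 1 holds the only number in the set; the other two values are limits (the limit of > 10000 nM in this assay, at which 2 of the 3 values shown sit). Compound 4 `CC(C)S(=O)(=O)N1CCc2nc(C#Cc3ccccc3)sc2C1` differs from compound 1 by isopropylsulfonyl in place of cyclopropylcarbonyl on an amine nitrogen in a ring. Going by the values given here, two measured steps bear on this: an at least 34-fold higher number from compound 1 to compound 2 (1.53 log units; beyond the scatter) and an at least 34-fold higher number from compound 1 to compound 3 (1.53 log units; beyond the scatter). Both exchange cyclopropyl on the carbonyl carbon for a group of more atoms and both lose heavily. Isopropylsulfonyl keeps a similar atom count to cyclopropylcarbonyl but replaces the carbonyl itself, so a loss beyond the scatter, smaller than those steps, is expected. Compound 4 is estimated at 1500 nM, between 300 nM and 8000 nM. This estimate means an expected 5.2-fold higher number from compound 1 to compound 4 (0.71 log units; beyond the scatter).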

Compound 4, half-maximal inhibitory concentration: 11 nM
Estimate against measurement, compound 4: 140-fold (2.13 log units) above; measured number outside the range, below it.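

In this assay, for the compounds shown here, isopropylsulfonyl in place of cyclopropylcarbonyl on the ring amine nitrogen gives a 26-fold lower number from compound 1 to compound 4 (1.42 log units; beyond the scatter), the first change at this position to strengthen inhibition rather than weaken it. A carbonyl on this nitrogen is therefore not required for inhibition in this series. No measured property in this set accounts for the gain.

Still open, as far as these compounds go, is whether the gain follows the sulfonyl or the isopropyl. A cyclopropylsulfonyl or methylsulfonyl group on the same nitrogen, or an isobutyryl amide, would separate the two.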